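A few compounds are considered here, and "the series" means these few. Any claim that something is new, unique, unknown or untested is made for them only; others in the source may bear on it.

Compound 2 `Nc1sc2c(c1C(=O)c1cccc3ccccc13)CCCC2` and compound 1 `Nc1sc2c(c1C(=O)c1ccc(I)c3ccccc13)CCC2` share a core and differ in two places. In an assay on isolated protein with adenosine receptor A1 (Homo sapiens) as the target, tested at 10 uM (on this read-out lower numbers stand for less inhibition and higher numbers for more inhibition at the one concentration tested (going by the name of the read-out)), compound 2 gives 2%, and compound 1 gives 3.3%, the two numbers lying within the usual scatter of each other, so neither can be set above the other. Compound 3 `Nc1sc2c(c1C(=O)c1ccc(I)c3ccccc13)CCCC2` is not yet measured; it differs from compound 2 by iodo in place of hydrogen on an aromatic carbon. Because compound 1 gives 3.3% with the same group in place, no step beyond the scatter is expected from compound 2 to compound 3: a number 1 percentage points higher from compound 2 to compound 3 (within the scatter). Compound 3 is expected to give 3%, between 0% and 12%.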

Compound 3, a percentage reported as inhibition, at one concentration (the size of the read-out at that concentration, not a potency): 15.3%
For compound 3 the middle estimate is 12.3 percentage points below the measured one; measured number above the stated range.
By their numbers in this assay, from the lowest: compounds 2 and 1 (each within the scatter of the next); then compound 3.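

With iodo in place of hydrogen on an aromatic carbon, para to a large group, this assay gives a number 13.3 percentage points higher from compound 2 to compound 3 (beyond the scatter), a modest step beyond the scatter. The earlier pair differed in two places and could not separate this change from the other, whereas this step shows that the position alone can move the read-out. Nothing available accounts for the step.

The compounds shown leave open whether the step is particular to iodo. Bromo, chloro, methoxy or an amine at the same carbon might tell.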